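Notes on the benzyl substitution step from compound 2

A few compounds are considered here, and "the series" means these few. Any claim that something is new, unique, unknown or untested is made for them only; others in the source may bear on it.

Compound 2 `COc1ccc(N2C(=O)N(Cc3ccccc3)c3ccccc3S2(=O)=O)cc1OC` stands as the higher of the two numbers in an assay on isolated protein for displacement of a labelled ligand from Orexin/Hypocretin receptor type 1 (Homo sapiens), with a stated time of 90 min; a higher number here means a weaker inhibitor, a lower number a stronger inhibitor: in this assay compound 2 gives 2000 nM, while compound 1 `COc1cc(F)c(CN2C(=O)N(c3cnc(OC)c(OC)c3)S(=O)(=O)c3ccccc32)c(F)c1` in this assay gives 2.51 nM, a far lower number. Within the data shown here, no single-change step between those two is available, so their values are simply noted side by side. Compound 3 `COc1ccc(N2C(=O)N(Cc3c(F)cc(F)cc3Cl)c3ccccc3S2(=O)=O)cc1OC` is not yet measured. It differs from compound 2 in one place: 2-chloro-4,6-difluorophenyl in place of phenyl on a saturated chain carbon bound to an amide-type nitrogen in a ring. With no measured step of this kind in the set, the size of the effect rests on the change alone. The expectation is a drop in the number for compound 3 beyond the scatter, the step estimated as a 13-fold lower number from compound 2 to compound 3 (1.12 log units; beyond the scatter). Compound 3 is estimated at 150 nM in this assay, with a range from 30 nM to 800 nM.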

Compound 3, inhibition constant: 25.1 nM
Beside the measured number, compound 3's estimate is 6.0-fold (0.78 log units) above it; measured number below the stated range.
By their numbers in this assay, from the lowest: compound 1; then compound 3; then compound 2.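

In this assay, the change from benzyl to 2-chloro-4,6-difluorobenzyl on a saturated chain carbon bound to an amide-type nitrogen in a ring gives an 80-fold lower number from compound 2 to compound 3 (1.90 log units; beyond the scatter) on the shared core. Among these compounds, this is the first single-change step, and it shows that the number at this position responds strongly to halogen substitution on the phenyl ring. Compounds 1 and 2 differ in more than one place and could not show this; no measured information here accounts for the size of the step.

The compounds shown do not separate the contribution of the chlorine from that of the two fluorines, since all three enter together. On these data alone, how a trifluoromethyl group, a nitrile or a carboxylic acid on this phenyl ring would compare also remains open.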